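A few compounds are considered here, and "the series" means these few. Any claim that something is new, unique, unknown or untested is made for them only; others in the source may bear on it.

Working notes on the series, read in a functional assay on HCT-116 cells (Homo sapiens), read by MTT assay, with a stated time of 72 h; on this read-out higher numbers stand for weaker inhibition and lower numbers for stronger inhibition. Compound 1, `CSc1ncnc2c1c(-c1ccsc1)cn2[C@@H]1O[C@H](CO)[C@@H](O)[C@H]1O`, gives > 20000 nM, which is a limit of the assay. Compound 2, `Nc1nc(N)c2c(-c3cccs3)cn([C@@H]3O[C@H](CO)[C@@H](O)[C@H]3O)c2n1`, gives > 20000 nM, also a limit. Compound 3, `Cc1nc(N)c2c(-c3cccs3)cn([C@@H]3O[C@H](CO)[C@@H](O)[C@H]3O)c2n1`, gives > 20000 nM, again a limit and not a number. For the measured compounds named here, the series so far therefore reads as the limit of > 20000 nM in this assay, at which 3 of the 3 values shown sit, and compound 3 has no measured place within it.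

Next comes compound 4, `C#Cc1cn([C@@H]2O[C@H](CO)[C@@H](O)[C@H]2O)c2nc(C)nc(N)c12`, with ethynyl in place of thiophen-2-yl on an aromatic carbon of the five-membered aromatic ring: ethynyl in place of thiophen-2-yl on an aromatic carbon.

Going by the values given here, the one measured step, a step that the two limits leave unreadable from compound 2 to compound 3, concerns methyl in place of amino, so it offers no size to carry over. Among the compounds with values here, no measured step covers the replacement of thiophen-2-yl by ethynyl either, which leaves the expectation in this assay poorly anchored. Within the data shown here, for compound 3 the reading of > 20000 nM is a limit, so the only step that could be read from it would run toward stronger inhibition.

The estimated step is an at least 2.0-fold lower number from compound 3 to compound 4 (0.30 log units; that floor lies within the scatter), a modest move in that direction if it appears at all. For compound 4 the expected value is 10000 nM, with an estimated range of 1500 nM to 20000 nM. A further report of only a limit remains more likely than not.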

Compound 4, half-maximal inhibitory concentration: > 20000 nM
Compound 4: no number, only a limit (the forecaster's own chance of this, stated with the estimate: 60%); at least 2.0-fold (0.30 log units) between middle value and limit.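

Compound 3 and compound 4 both stand only as limits in this assay, so no size can be read for the step between them, ethynyl in place of thiophen-2-yl. The compounds shown leave open whether any change on the shared core gives a measured number and how these compounds rank, as the series so far reads: the limit of > 20000 nM in this assay, at which 4 of the 4 values shown sit.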